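Swapping Phenyl for Pyridin-4-yl on the Shared Core

The compounds below may be only part of what the source reports. "The series", "measured", "known", "first", "only" and "open" are said of these compounds alone.

Compound 2 `O=S(=O)(Nc1ccc(F)c(C#Cc2cnc3[nH]nc(-c4ccccc4)c3c2)c1F)c1cccnc1` gives 200 nM in a functional assay on COLO 205 cells (Homo sapiens) for antiproliferative activity, read by MTT assay, with a stated time of 68 h (on this read-out higher numbers stand for weaker inhibition and lower numbers for stronger inhibition), and stands at the upper end of the two numbers recorded so far; compound 1 `Cc1n[nH]c2ncc(C#Cc3c(F)ccc(NS(=O)(=O)c4cccnc4)c3F)cc12` gives 148 nM, and the step of a 1.4-fold higher number from compound 1 to compound 2 (0.13 log units; within the scatter) lies within the scatter. Compound 3 `O=S(=O)(Nc1ccc(F)c(C#Cc2cnc3[nH]nc(-c4ccncc4)c3c2)c1F)c1cccnc1` differs from compound 2 by pyridin-4-yl in place of phenyl on an aromatic carbon. Going by the values given here, no measured step matches this change; only the step from compound 1 to compound 2 touches the same aromatic carbon, and it stayed within the scatter. Compound 3 is therefore expected to show no step beyond the scatter, no change at the digits printed from compound 2 to compound 3 (within the scatter). The estimate for compound 3 is 200 nM, with a range from 80 nM to 500 nM.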

Compound 3, half-maximal inhibitory concentration: 78 nM
Beside the measured number, compound 3's estimate is 2.6-fold (0.41 log units) above it, and the stated range ends above it.
By their numbers in this assay, from the lowest: compounds 3, 1 and 2 (each within the scatter of the next, the first and the last beyond it).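

In this assay, going by these compounds alone, this aromatic carbon no longer looks indifferent to what it carries: pyridin-4-yl in place of phenyl gives a 2.6-fold lower number from compound 2 to compound 3 (0.41 log units; beyond the scatter) and is the only step here beyond the scatter. Against methyl, the same group gives a 1.9-fold lower number from compound 1 to compound 3 (0.28 log units; within the scatter) and stays within the scatter, so a six-membered aromatic ring is set apart from phenyl by its one hetero atom, not from the small methyl group. No measured evidence bears on what lies behind this step.

The compounds shown leave open whether the place of the ring nitrogen matters, as pyridin-3-yl would show. As far as these compounds go, how an amine or a carboxylic acid on this carbon would compare also remains open.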